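A few compounds are considered here, and "the series" means these few. Any claim that something is new, unique, unknown or untested is made for them only; others in the source may bear on it.

Series notes. Compound 1 `COC(=O)/C=C/c1cccc(N(Cc2ccc(/C=C/C(=O)NC(C)(C)C)cc2)C(=O)C2CCCCC2)c1` and compound 2 `COC(=O)/C=C/c1cccc(N(Cc2ccc(/C=C/c3ccc(OC)cc3)cc2)C(=O)C2CCCCC2)c1` share one core and differ in a single place, on a double-bonded chain carbon bound to a double-bonded chain carbon. In an assay on isolated protein with Bile acid receptor (Homo sapiens) as the target (on this read-out higher numbers stand for an effect only at larger amounts of compound and lower numbers for an effect already at smaller amounts), compound 1 shows > 1000 nM, which is a limit of the assay and not a number; this is the limit of > 1000 nM in this assay, at which 1 of the 2 values shown sits. In this assay, going by the values given here, compound 2 gives 208 nM, the one number in the set. Among the compounds with values here, the single measured step is an at least 4.8-fold lower number from compound 1 to compound 2 (0.68 log units; beyond the scatter). Compound 3 `COC(=O)/C=C/c1cccc(N(Cc2ccc(/C=C/c3c(Cl)cccc3Cl)cc2)C(=O)C2CCCCC2)c1` is not yet measured; it differs from compound 2 in one place: 2,6-dichlorophenyl in place of 4-methoxyphenyl on a double-bonded chain carbon bound to a double-bonded chain carbon. The measured step exchanged a (tert-butyl)carbamoyl for an aryl group, whereas the step to compound 3 exchanges one aryl for another, 4-methoxyphenyl leaving and 2,6-dichlorophenyl entering, so the measured step bears on it only loosely and sets a frame rather than a direction. Within the data shown here, no measured pair compares two aryl groups at that place. The step of a 1.2-fold higher number from compound 2 to compound 3 (0.08 log units; within the scatter) is therefore expected to stay within the scatter or to be at most modest, in either direction. The estimate for compound 3 in this assay is 250 nM, with a range from 70 nM to 900 nM.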

Compound 3, half-maximal effective concentration: 150 nM
Beside the measured number, compound 3's estimate is 1.7-fold (0.22 log units) above it, and the stated range covers the measured number.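

In this assay, going by these compounds alone, the step is a 1.4-fold lower number from compound 2 to compound 3 (0.14 log units; within the scatter), which gives the first comparison of two aryl groups on a double-bonded chain carbon bound to a double-bonded chain carbon: 4-methoxyphenyl and 2,6-dichlorophenyl, each a six-membered aromatic ring of carbon only, stay within the scatter of each other, although only the former carries a hydrogen-bond acceptor. The exchange of (tert-butyl)carbamoyl for a second aryl group gives an at least 6.6-fold lower number from compound 1 to compound 3 (0.82 log units; beyond the scatter), so among the three compounds both aryl groups stand apart from the (tert-butyl)carbamoyl, and the earlier step no longer rests on 4-methoxyphenyl alone. Compound 1 remains a limit and not a number, so both steps from it give only a minimum size: the limit of > 1000 nM in this assay, at which 1 of the 3 values shown sits.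

The compounds shown leave open whether the chlorine atoms or the methoxy group contribute anything at all, as a plain phenyl, a 4-chlorophenyl or a 2-chlorophenyl at this place would be needed to separate them. They also leave open how a pyridine ring, or an aryl group bearing a carboxylic acid or an amine, would read out here.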